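The source may hold more compounds than are shown below. What is called first, only, known or untested is meant among the compounds shown, and "the series" means these compounds.

Measured so far:
compound 1, `Cc1cc(-c2ccccc2F)cc(C)c1Oc1cc(N)nc(Nc2ccc(C#N)cc2)n1` — in a toxicity assay on MT4 cells (Homo sapiens) for cytotoxicity, read by MTT assay (a lower number here means that less compound is tolerated, a higher number that more compound is tolerated), compound 1 gives 29300 nM
compound 2, `Cc1cc(-c2cccc(F)c2)cc(C)c1Oc1cc(N)nc(Nc2ccc(C#N)cc2)n1` — in this assay compound 2 gives 24700 nM
compound 3, `Cc1cc(-c2ccccc2F)ccc1Oc1cc(N)nc(Nc2ccc(C#N)cc2)n1` — in this assay compound 3 gives 29500 nM

Compound 4, `Cc1cc(-c2cccc(F)c2)ccc1Oc1cc(N)nc(Nc2ccc(C#N)cc2)n1`, has not yet been measured. It differs from compound 3 by 3-fluorophenyl in place of 2-fluorophenyl on an aromatic carbon. The same kind of change links compound 1 to compound 2, (3-fluorophenyl in place of 2-fluorophenyl on an aromatic carbon), although there the place is meta to two methyl groups rather than meta to a methyl group. The two cores differ by hydrogen in place of methyl on an aromatic carbon, a step of a 1.0-fold higher number from compound 1 to compound 3 (0.00 log units; within the scatter) in this assay. Because a 1.2-fold lower number from compound 1 to compound 2 (0.07 log units; within the scatter) stayed within the scatter, the step from compound 3 to compound 4 in this assay is expected to be similarly small, about a 1.1-fold lower number from compound 3 to compound 4 (0.04 log units; within the scatter). Compound 4 is therefore estimated at 27000 nM, with a likely range from 14000 nM to 55000 nM.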

Compound 4, half-maximal cytotoxic concentration: 11300 nM
Beside the measured number, compound 4's estimate is 2.4-fold (0.38 log units) above it; the whole stated range lies above it.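

In this assay, 3-fluorophenyl in place of 2-fluorophenyl gives a 2.6-fold lower number from compound 3 to compound 4 (0.42 log units; beyond the scatter), yet this step does not stand apart from the same change on the other core: the same change on two cores in this assay, a 1.2-fold lower number (0.07 log units; within the scatter) from compound 1 to compound 2 and a 2.6-fold lower number (0.42 log units; beyond the scatter) from compound 3 to compound 4, 2.2-fold (0.34 log units) apart, within the scatter of two such steps. Hydrogen in place of methyl, which gives a 2.2-fold lower number from compound 2 to compound 4 (0.34 log units; beyond the scatter), reads the same way: the same change on two cores in this assay, a 1.0-fold higher number (0.00 log units; within the scatter) from compound 1 to compound 3 and a 2.2-fold lower number (0.34 log units; beyond the scatter) from compound 2 to compound 4, 2.2-fold (0.34 log units) apart, within the scatter of two such steps. Both changes are thus compatible with carrying over from one core to the other, but a single pair of steps for each change shows neither that the size of the step is kept nor that it depends on the core.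

The compounds shown leave open how a chlorine or a methoxy group in place of the fluorine would behave on either core.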